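The source may hold more compounds than are shown below. What is called first, only, known or untested is meant among the compounds shown, and "the series" means these compounds.

Of the compounds shown here, three have been measured in an ADME assay on HepG2 cells (Homo sapiens) for inhibition, with a stated time of 72 h (a higher number here means that more compound is needed for the effect, a lower number that less compound is needed), and all three come back at a limit. Compound 1 `C=C(C)C(=O)Nc1cccc(-c2nc3ccccc3s2)c1` gives > 25000 nM, which is a limit of the assay rather than a number. Compound 2 `O=C(Nc1cccc(-c2nc3ccccc3s2)c1)c1cnccc1Cl` gives > 25000 nM in this assay, again a limit. Compound 3 `Cc1ccc(-c2nc3ccccc3o2)cc1NC(=O)c1cnccc1Cl`, the starting point of the step followed here, gives > 25000 nM in this assay, once more a limit. Going by the values given here, because of the limit of > 25000 nM in this assay, at which 3 of the 3 values shown sit, the one step between measured compounds, a step that the two limits leave unreadable from compound 1 to compound 2, cannot be read, since both of its ends sit at the limit. Compound 3 therefore stands where every measured compound stands, at the limit, with no readable step leading away from it.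

Compound 4 `O=C(Nc1cc(-c2nc3ccccc3o2)ccc1F)c1cnccc1Cl` differs from compound 3 by fluoro in place of methyl on an aromatic carbon. Among the compounds with values here, no measured step concerns this change, and the only recorded step, from compound 1 to compound 2, gives no size at all. Nothing in the measurements suggests that compound 4 should move off the limit. The step expected for compound 4 in this assay, a step that the limit leaves unreadable from compound 3 to compound 4, is none beyond the scatter. Compound 4 is therefore estimated at 30000 nM in this assay, with a range from 8000 nM to 100000 nM, and most likely the assay will again report only a limit.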

Compound 4, half-maximal effective concentration: > 25000 nM
Compound 4 was reported as a limit (the forecaster's own chance of this, stated with the estimate: 80%); the middle value is on the limit's open side.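

No step can be read between compound 3 and compound 4 in this assay, because both compounds sit at a limit of the assay: the limit of > 25000 nM in this assay, at which 4 of the 4 values shown sit. The compounds shown leave open how much of any of them is actually needed for the effect, and whether fluoro in place of methyl changes that amount at all.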